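The compounds below may be only part of what the source reports. "The series", "measured", "known", "first", "only" and "open" are said of these compounds alone.

Measured compounds:
compound 1 `O=C(Nc1cccc(-n2cc(-c3ccncc3)c(-c3cc(O)cc(Cl)c3)n2)c1)Nc1ccc(Cl)c(Cl)c1`: -35%
compound 2 `COc1cc(Cl)cc(-c2nn(-c3cccc(NC(=O)Nc4ccc(Cl)c(Cl)c4)c3)cc2-c2ccncc2)c1`: -20%

In a functional assay on NCI-H23 cells (Homo sapiens) for inhibition, read by sulforhodamine B assay, with a stated time of 48 h, tested at 100 uM (on this read-out lower numbers stand for a stronger effect and higher numbers for a weaker effect at the one concentration tested), compound 2 gives -20%, the higher of the two numbers; compound 1 gives -35%. Among the measured compounds shown here, the one step known, a number 15 percentage points higher from compound 1 to compound 2 (beyond the scatter), came from methyl in place of hydrogen on an oxygen on an aromatic ring. Compound 3 `COc1cc(Cl)cc(-c2nn(-c3cccc(NC(=O)c4cccc(C(F)(F)F)c4)c3)cc2-c2ccncc2)c1` differs from compound 2 at another place: 3-(trifluoromethyl)phenyl in place of (3,4-dichlorophenyl)amino on a carbonyl carbon. For the measured compounds named here, no measured step touches this part of the molecule, so neither direction nor size can be read from the data. The step is expected to stay near zero, a number 15 percentage points higher from compound 2 to compound 3 (beyond the scatter). Compound 3 is estimated at -5%, within -40% to 30%.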

Compound 3, a percentage reported as activity, at one concentration (the size of the read-out at that concentration, not a potency): 27%
Compound 3: the middle estimate sits 32 percentage points below what was measured; measured number inside the range.
By their numbers in this assay, from the lowest: compound 1; then compound 2; then compound 3.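

In this assay the group on the carbonyl carbon carries more weight than the methyl on the oxygen: the earlier step was a number 15 percentage points higher from compound 1 to compound 2 (beyond the scatter), whereas 3-(trifluoromethyl)phenyl in place of (3,4-dichlorophenyl)amino gives a number 47 percentage points higher from compound 2 to compound 3 (beyond the scatter). This large step points to a weaker effect. Nothing available explains it.

The swap changes both the ring's substituents and the nitrogen on the carbonyl carbon, so the two changes cannot be separated. A (3-(trifluoromethyl)phenyl)amino group on that carbon would keep the nitrogen and change only the ring substituents, and the compounds shown leave its result open.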